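Swapping One Aromatic Ring on a Weakly Cytotoxic Scaffold

The compounds below may be only part of what the source reports. "The series", "measured", "known", "first", "only" and "open" are said of these compounds alone.

Compound 1, `Cc1ccsc1-c1cc(-c2ccco2)cc(-c2ccccc2Cl)n1`: 24000 nM
Compound 2, `Cc1ccc(-c2cc(-c3ccoc3)cc(-c3ccc(Cl)s3)n2)o1`: 26500 nM

Of the compounds shown here, two have been measured in a functional assay on HeLa cells (Homo sapiens) for cytotoxicity, read by ELISA, with a stated time of 4 days; a lower number here means a stronger inhibitor, a higher number a weaker inhibitor. Compound 1 gives 24000 nM. Compound 2 gives 26500 nM, the highest of the two numbers, but the gap to compound 1 is within the scatter, so the two compounds cannot be ordered on these data. Within the data shown here, no pair of measured compounds differing in one place is available, so no measured step sets a scale for the change that follows.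

Compound 3, `Cc1ccc(-c2cc(-c3ccoc3)cc(-c3ccc(Cl)s3)n2)cc1`, is the untested compound. It differs from compound 2 in one place: 4-methylphenyl in place of 5-methylfuran-2-yl on an aromatic carbon. Among the measured compounds shown here, with both measured compounds showing values of the same size, and no measured step to lean on, the expected step in this assay from compound 2 to compound 3 is estimated to be small, a 1.1-fold lower number from compound 2 to compound 3 (0.03 log units; within the scatter), with no direction beyond the scatter. Compound 3 is thus expected to give about 25000 nM, in a range from 8000 nM to 80000 nM.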

Compound 3, half-maximal inhibitory concentration: 28700 nM
For compound 3 the middle estimate is 1.1-fold (0.06 log units) below the measured one, and the stated range covers the measured number.
By their numbers in this assay, from the lowest: compounds 1, 2 and 3 (each within the scatter of the next).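

In this assay, among these compounds, replacing 5-methylfuran-2-yl with 4-methylphenyl on the aromatic carbon next to the ring nitrogen gives a 1.1-fold higher number from compound 2 to compound 3 (0.03 log units; within the scatter), the first measured change in one place. At this position, the read-out does not separate a five-membered aromatic ring with 1 hetero atom from a six-membered aromatic ring of carbon only, and the hydrogen-bond acceptor counted in the leaving group can be lost without a change beyond the scatter. No measured evidence bears on this result, so the similarity of the two values remains unexplained.

Among the compounds shown here, this single step covers only two aromatic rings, each carrying a methyl group. On these data alone, whether an amine, a carboxylic acid or a longer chain on this carbon would move the number beyond the scatter remains open.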